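The source may report more compounds than this note shows. Statements on the series, on what has been measured and on what is new or still open speak of the compounds shown alone.

Measured in a functional assay on L02 cells (Homo sapiens) for cytotoxicity, read by MTT assay, with stated times of 48 h and 4 h; on this read-out lower numbers stand for stronger inhibition and higher numbers for weaker inhibition:
- compound 1 `COc1ccc(/C=C/c2nc(NCCN(C(C)C)C(C)C)c3ccccc3n2)cc1OC`: > 100000 nM (a limit)
- compound 2 `COc1ccc(/C=C/c2nc(NCCN(C)C)c3cc(Cl)ccc3n2)cc1OC`: 80500 nM
- compound 3 `COc1ccc(/C=C/c2nc(NCCN(C(C)C)C(C)C)c3cc(Cl)ccc3n2)cc1OC`: > 100000 nM (a limit)

Compound 3 reads > 100000 nM, which is a limit and not a number. It stands with compound 1 at the limit of > 100000 nM in this assay, at which 2 of the 3 values shown sit.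

Compound 4 `COc1ccc(/C=C/c2nc(NCCCCN)c3cc(Cl)ccc3n2)cc1OC` keeps the chloro group and the shared core but carries 2-aminoethyl in place of diisopropylamino on a saturated chain carbon, two bonds along the chain from a nitrogen on an aromatic ring.

The nearest measured change at this place, dimethylamino to diisopropylamino, is an at least 1.2-fold higher number from compound 2 to compound 3 (0.09 log units; that floor lies within the scatter). The chloro change, a step that the two limits leave unreadable from compound 1 to compound 3, cannot be sized and lies elsewhere on the molecule. Among the measured compounds shown here, no measured compound carries 2-aminoethyl at this place, so the expectation rests on compound 2, the only one with a number, at 80500 nM. A modest move toward stronger inhibition is expected, estimated as an at least 1.6-fold lower number from compound 3 to compound 4 (0.22 log units; that floor lies within the scatter). For compound 4 the expected value is 60000 nM, with an estimated range of 20000 nM to 100000 nM.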

Compound 4, half-maximal inhibitory concentration: > 100000 nM
Compound 4: no number, only a limit; the forecaster's own chance of this, stated with the estimate: 35%; at least 1.6-fold (0.22 log units) between middle value and limit.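

In this assay, among the compounds shown here, compound 4 gives > 100000 nM, which is a limit, so a primary amine at the end of a 4-aminobutyl chain joins the diisopropylamino compounds at the same ceiling: the limit of > 100000 nM in this assay, at which 3 of the 4 values shown sit. Against compound 2, the only compound with a number, the change reads as an at least 1.2-fold higher number from compound 2 to compound 4 (0.09 log units; that floor lies within the scatter), so even this larger change of group at this place shows no separation from compound 2 beyond the scatter. The steps with a limit at both ends cannot be read.

From the compounds shown here alone, how far these groups truly lie apart stays open, as does whether any group at this place can give a number clearly lower than that of compound 2. A morpholine or a carboxylic acid at the chain end, or a shorter chain bearing the same primary amine, would test this.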